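This account rests on a few compounds, and the source may have more. Where it says the series, first, only, none or still open, it means among the compounds named here.

Measured compounds:
compound 1 `CCC(=O)Nc1cc(C(=O)Nc2ccc(Br)cc2)ccc1OC` 90.4 uM
compound 2 `CCC(=O)Nc1cc(C(=O)Nc2cccc(SC)c2)ccc1OC` 324 uM
compound 3 `COc1ccc(C(=O)Nc2ccccc2)cc1NC(=O)C(C)Cl` 200 uM

In an ADME assay on MDCK cells (Canis lupus familiaris) for cytotoxicity, read by cytopathic effect, with a stated time of 48 h (on this read-out lower numbers stand for higher toxicity in this test and higher numbers for lower toxicity in this test), compound 1 gives 90.4 uM, the lowest of the three numbers. Compound 3 gives 200 uM. Compound 2 gives 324 uM, the furthest from compound 1 of the two. Compound 4 `CCC(=O)Nc1cc(C(=O)Nc2ccccn2)ccc1OC` is still to be tested in this assay. It differs from compound 1 in one place: pyridin-2-yl in place of 4-bromophenyl on an amide-type nitrogen. Within the data shown here, the one measured step that touches the same position is a 3.6-fold higher number from compound 1 to compound 2 (0.55 log units; beyond the scatter), a modest rise. Compound 3 differs from compound 1 in more than one place, so its value carries no separate lesson on this position. Among the measured compounds shown here, with only that one step for guidance, the change in compound 4 is expected to move the number in the same direction, by a modest amount or none beyond the scatter. Compound 4 is therefore estimated at 180 uM, within 70 uM to 450 uM. The estimated step is a 2.0-fold higher number from compound 1 to compound 4 (0.30 log units; within the scatter).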

Compound 4, half-maximal toxic concentration: > 668 uM
Compound 4: a limit, no number (the forecaster's own chance of this, stated with the estimate: 15%); at least 3.7-fold (0.56 log units) between middle value and limit.
By their numbers in this assay, from the lowest: compound 1; then compounds 3 and 2 (each within the scatter of the next). At a limit, above all of these: compound 4.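

In this assay the value of compound 4 is a limit and not a number: the limit of > 668 uM in this assay, at which 1 of the 4 values shown sits. Pyridin-2-yl in place of 4-bromophenyl gives an at least 7.3-fold higher number from compound 1 to compound 4 (0.86 log units; beyond the scatter), so this position on the amide-type nitrogen can carry a change that moves the number beyond the scatter in the upward direction, and the earlier step, a 3.6-fold higher number from compound 1 to compound 2 (0.55 log units; beyond the scatter), did not mark the top of the range. Pyridin-2-yl in place of 3-(methylsulfanyl)phenyl also gives an at least 2.0-fold higher number from compound 2 to compound 4 (0.31 log units; beyond the scatter), so the ring with a hetero atom stands apart from both carbon-only rings compared here.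

On these data alone, the true size of both new steps stays open, since each ends at a limit. As far as these compounds go, whether the rise follows from losing the bromine or from gaining the ring nitrogen also stays open; a plain phenyl or a pyridin-4-yl on this nitrogen, with the rest of compound 1 kept, would separate the two.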